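The compounds below may be only part of what the source reports. "The series", "measured", "known", "first", "only" and "open" are said of these compounds alone.

In a functional assay on SK-OV-3 cells (Female gonad, Homo sapiens) for antiproliferative activity (on this read-out higher numbers stand for an effect only at larger amounts of compound and lower numbers for an effect already at smaller amounts), compound 2 `c1ccc(-c2cc(-c3cccs3)nc(-c3cccs3)c2)nc1` gives 118000 nM. Compound 1 `c1coc(-c2ccnc(-c3cccs3)c2)c1` gives 118000 nM and compound 3 `c1coc(-c2ccnc(-c3ccco3)c2)c1` gives 118000 nM, so compound 2 stands level with both within the scatter. The only measured step among these compounds, no change at the digits printed from compound 1 to compound 3 (within the scatter), exchanges thiophen-2-yl for furan-2-yl and is a different change from the one considered here. Compound 4 `c1coc(-c2cc(-c3cccs3)nc(-c3cccs3)c2)c1` differs from compound 2 by furan-2-yl in place of pyridin-2-yl on an aromatic carbon. Going by the values given here, no measured step covers this exchange, and the expectation rests only on all three measured compounds sitting at one level. Compound 4 is therefore expected to show no step beyond the scatter, no change at the digits printed from compound 2 to compound 4 (within the scatter). In this assay compound 4 is estimated at 118000 nM, between 40000 nM and 350000 nM.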

Compound 4, half-maximal effective concentration: 118000 nM
Compound 4: middle estimate and measured number agree at the digits printed; low and high end bracket the measured number.
By their numbers in this assay, from the lowest: compounds 1, 2, 3 and 4 (each within the scatter of the next).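

In this assay, the aromatic carbon opposite the ring nitrogen accepts furan-2-yl in place of pyridin-2-yl with no change at the digits printed from compound 2 to compound 4 (within the scatter) in the read-out. A second change, thiophen-2-yl in place of hydrogen on an aromatic carbon, likewise gives no change at the digits printed from compound 1 to compound 4 (within the scatter) at the printed digits. No evidence is available that would explain either result. The compounds shown leave open whether an amine or a carboxylic acid at the position opposite the ring nitrogen would depart from this level.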